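A few compounds are considered here, and "the series" means these few. Any claim that something is new, unique, unknown or untested is made for them only; others in the source may bear on it.

Of the compounds shown here, three have been tested in a functional assay on the whole organism (strain Wister albino) for inhibition, with Rattus norvegicus as the target, read by paw edema, with stated times of 1 h and 24 h, at a dose of 50 mg/kg by the intraperitoneal route; a higher number here means more inhibition at the dose given (going by the name of the read-out), a lower number less inhibition. Compound 1 `CCOC(=O)c1c(-c2ccc(Cl)cc2)cc(-c2ccccc2)nc1N1CCCCC1` gives 36.4%. Compound 2 `CCOC(=O)c1c(-c2ccc(Cl)c(Cl)c2)cc(-c2ccccc2)nc1N1CCCCC1` gives 48.9%, and compound 3 `CCOC(=O)c1c(-c2ccc(Cl)cc2)cc(-c2ccccc2)nc1Nc1ccccc1` gives 46.5%. Compound 2 has the highest of the three numbers, though its gap to compound 3 lies within the scatter; only the gap to compound 1 is beyond it, as the step of a number 12.5 percentage points higher from compound 1 to compound 2 (beyond the scatter) shows, which comes from chloro in place of hydrogen on an aromatic carbon.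

The next compound is compound 4 `CCOC(=O)c1c(-c2ccc(Cl)c(Cl)c2)cc(-c2ccccc2)nc1Nc1ccc(C)cc1`. Relative to compound 2 the change is (4-methylphenyl)amino in place of piperidin-1-yl on an aromatic carbon.

For the measured compounds named here, one measured step bears on this change: a number 10.1 percentage points higher from compound 1 to compound 3 (beyond the scatter), where anilino replaced piperidin-1-yl on an aromatic carbon. Going by the values given here, compound 4 carries the closely related (4-methylphenyl)amino group, and no measured step tells what the added methyl does. Taking the anilino step as the guide, an upward step of about the same size is expected in this assay, namely a number 10.1 percentage points higher from compound 2 to compound 4 (beyond the scatter). Compound 4 is therefore estimated at 59%, within a range from 46% to 72%.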

Compound 4, a percentage reported as inhibition, in the whole organism at one dose (the size of the read-out at that dose, not a potency): 40.8%
The estimate for compound 4 lay 18.2 percentage points above the measured number, and the stated range ends above it.
By their numbers in this assay, from the lowest: compounds 1, 4, 3 and 2 (each within the scatter of the next, the first and the last beyond it).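

On the core carrying the 3,4-dichlorophenyl group, placing (4-methylphenyl)amino instead of piperidin-1-yl at this position gives a number 8.1 percentage points lower from compound 2 to compound 4 (within the scatter) in this assay, so the two cannot be told apart in this test. The earlier step, a number 10.1 percentage points higher from compound 1 to compound 3 (beyond the scatter), therefore does not reappear here, which shows that an aromatic amino group at this position does not raise the number in every setting. Nothing available explains why the two settings differ.

Still open, on these data alone, is how much the methyl group itself counts, and how much the second chloro on the neighbouring aromatic group shapes the effect of this change. Also open, as far as these compounds go, is how a morpholin-4-yl group at this position, or a free carboxylic acid in place of the ethoxycarbonyl group, would behave.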